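Anilino variation on the shared core: compound 3

This account rests on a few compounds, and the source may have more. Where it says the series, first, only, none or still open, it means among the compounds named here.

The series keeps one core and varies the aryl group on a nitrogen on an aromatic ring. Compound 1 `COc1cccc(/C=C/C(=O)c2sc(Nc3ccc(Cl)cc3)nc2C)c1` is one member. In a functional assay on Bel-7402 cells (Homo sapiens) for cytotoxicity, read by MTT assay (on this read-out lower numbers stand for stronger inhibition and higher numbers for weaker inhibition), compound 1 gives > 25000 nM, which is a limit of the assay. Compound 2 `COc1cccc(/C=C/C(=O)c2sc(Nc3ccccc3C)nc2C)c1` differs only in that aryl group. In this assay compound 2 gives > 25000 nM, likewise a limit. The step that the two limits leave unreadable from compound 1 to compound 2 is thus unreadable, as both values sit at the limit of > 25000 nM in this assay, at which 2 of the 2 values shown sit. Compound 3 `COc1cccc(/C=C/C(=O)c2sc(Nc3cccc(Cl)c3)nc2C)c1` carries 3-chlorophenyl in place of 2-methylphenyl on a nitrogen on an aromatic ring. Among the measured compounds shown here, no measured step of readable size bears on this change. Compound 3 is expected at 30000 nM (range 12000 nM to 100000 nM), a step that the limit leaves unreadable from compound 2 to compound 3 expected to stay within the scatter, most likely again reported only as a limit.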

Compound 3, half-maximal inhibitory concentration: > 25000 nM
Compound 3 ended at the assay's limit; the forecaster's own chance of this, stated with the estimate: 80%; the middle value does not contradict the limit.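

No step among compound 1, compound 2 and compound 3 can be read in this assay, as each value is a limit: the limit of > 25000 nM in this assay, at which 3 of the 3 values shown sit.

The compounds shown leave open whether any aryl group on this nitrogen gives a measurable value, and how these three aryl groups rank.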